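This account rests on a few compounds, and the source may have more. Where it says the series, first, only, none or still open, it means among the compounds named here.

Of the compounds shown here, three have so far been measured in an ADME assay on cells (T-cell, Mus musculus, strain BALB/c) for cytotoxicity, read by MTT assay, with a stated time of 48 h; a lower number here means that less compound is tolerated, a higher number that more compound is tolerated. Compound 1 `COC(=O)c1cc(O)ccc1OC(=O)COc1cc(O)c2c(=O)cc(-c3ccccc3)oc2c1` gives 263000 nM. Compound 2 `COC(=O)c1c(C)cccc1OC(=O)COc1cc(O)c2c(=O)cc(-c3ccccc3)oc2c1` gives 298000 nM. Compound 3 `COC(=O)c1cccc(Cl)c1OC(=O)COc1cc(O)c2c(=O)cc(-c3ccccc3)oc2c1` gives 366000 nM, which is the highest of the three numbers, yet it sits within the scatter of both other compounds, so no real order among them can be read. The three compounds share one core and differ only in the group on an oxygen next to a carbonyl group, and each exchange of that group left the number essentially where it was: a 1.1-fold higher number from compound 1 to compound 2 (0.05 log units; within the scatter), a 1.4-fold higher number from compound 1 to compound 3 (0.14 log units; within the scatter) and a 1.2-fold higher number from compound 2 to compound 3 (0.09 log units; within the scatter).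

Compound 4 `COC(=O)c1cc(Br)ccc1OC(=O)COc1cc(O)c2c(=O)cc(-c3ccccc3)oc2c1` has not yet been measured. It differs from compound 3 at that same place: 4-bromo-2-(methoxycarbonyl)phenyl in place of 2-chloro-6-(methoxycarbonyl)phenyl on an oxygen next to a carbonyl group. This exchange is also expected to leave the number within the scatter, because a 1.4-fold higher number from compound 1 to compound 3 (0.14 log units; within the scatter) and the other two exchanges of this group all stayed within it. The expected step is therefore a 1.1-fold lower number from compound 3 to compound 4 (0.04 log units; within the scatter), meaning no shift beyond the scatter in either direction. For compound 4 the estimated value in this assay is 330000 nM, with a range from 200000 nM to 550000 nM.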

Compound 4, half-maximal cytotoxic concentration: > 450000 nM
Compound 4 ended at the assay's limit (the forecaster's own chance of this, stated with the estimate: 5%); middle value at least 1.3-fold (0.13 log units) from the limit.
By their numbers in this assay, from the lowest: compounds 1, 2 and 3 (each within the scatter of the next). At a limit, above all of these: compound 4.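

In this assay, compound 4 is the only compound shown that ends at a limit of the assay rather than at a number: the limit of > 450000 nM in this assay, at which 1 of the 4 values shown sits. The steps to it are therefore floors only (an at least 1.2-fold higher number from compound 3 to compound 4 (0.08 log units; that floor lies within the scatter)), (an at least 1.5-fold higher number from compound 2 to compound 4 (0.17 log units; that floor lies within the scatter)) and (an at least 1.7-fold higher number from compound 1 to compound 4 (0.23 log units; that floor lies within the scatter)), and since each floor lies within the scatter, none of them proves a real rise, although the true gaps could be wider. From the compounds shown here alone, what is new is that 4-bromo-2-(methoxycarbonyl)phenyl, on an oxygen next to a carbonyl group, brings no drop in the number, and that the size of the exchange for 2-chloro-6-(methoxycarbonyl)phenyl stays unknown, unlike the earlier exchanges at this place, which could all be read in full.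

Going by these compounds, the true value of compound 4 stays open, and so does whether an amine or a carboxylic acid on this aromatic ring, or a longer chain in place of methoxycarbonyl, would move the number beyond the scatter. Every compound shown keeps the shared core, so what a change to that core would do also remains open.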